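Ring contraction on the sulfonamide side chain

This account rests on a few compounds, and the source may have more. Where it says the series, first, only, none or still open, it means among the compounds named here.

Compound 1 `NC(=O)[C@@H](CCC(F)(F)F)N(C[C@H]1CCCCO1)S(=O)(=O)c1ccc(Cl)cc1` stands highest of the two compounds measured in a physicochemical assay for lipophilicity, read by HPLC, measured as octanol-water partition, at pH 7.4 (a higher number here means a more lipophilic compound, a lower number a more polar compound), where compound 1 gives 4.3. Going by the values given here, the only comparator is compound 2 `NC(=O)[C@@H](CCC(F)(F)F)N(C[C@H]1CCCO1)S(=O)(=O)c1ccc(Cl)cc1`, which gives 3.6 in this assay; the step of a number 0.70 log units lower from compound 1 to compound 2 (beyond the scatter) is the one that bears on the present change. Compound 3 `NC(=O)[C@@H](CCC(F)(F)F)N(C[C@@H]1CCO1)S(=O)(=O)c1ccc(Cl)cc1` differs from compound 1 as follows: oxetan-2-yl in place of oxan-2-yl on a saturated chain carbon bound to a sulfonamide nitrogen. Since the smaller ring of compound 2 already lowered this assay beyond the scatter, a further drop is expected for compound 3, estimated as a number 1.40 log units lower from compound 1 to compound 3 (beyond the scatter). Compound 3 is therefore expected at 2.9, within 2.5 to 3.3.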

Compound 3, distribution coefficient: 2.6
For compound 3 the middle estimate is 0.30 log units above the measured one, within the range that was stated.
By their numbers in this assay, from the lowest: compound 3; then compound 2; then compound 1.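

In this assay the series now spans three ring sizes at this position, and the number falls with each contraction, with a number 1.70 log units lower from compound 1 to compound 3 (beyond the scatter) and a number 1.00 log units lower from compound 2 to compound 3 (beyond the scatter). The change to oxetan-2-yl therefore extends the fall already seen with oxolan-2-yl, and none of the three compounds goes against this order. Nothing available here accounts for this fall.

From the compounds shown here alone, whether an open-chain methoxyethyl group or an azetidin-2-yl ring would fit the same order remains open. Going by these compounds, how these compounds compare outside this assay also remains open.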